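The source may hold more compounds than are shown below. What is called first, only, known or untested is meant among the compounds shown, and "the series" means these compounds.

Of the compounds shown here, three have been measured in a functional assay on HeLa cells (Homo sapiens) for antiproliferative activity, with a stated time of 24 h; on this read-out higher numbers stand for weaker inhibition and lower numbers for stronger inhibition. Compound 1 `NC(=O)c1c(NC(=O)c2ccccc2Br)sc2c1CCN(C(=S)Nc1ccccc1Cl)C2` gives 46900 nM; compound 2 `Cc1ccccc1C(=O)Nc1sc2c(c1C(N)=O)CCN(C(=S)Nc1ccccc1Cl)C2` gives 35300 nM; compound 3 `NC(=O)c1c(NC(=O)c2ccc(C(F)(F)F)cc2)sc2c1CCN(C(=S)Nc1ccccc1Cl)C2` gives 44000 nM. Compound 2 carries nominally the lowest of the three numbers, but its steps to the others, a 1.3-fold lower number from compound 1 to compound 2 (0.12 log units; within the scatter) and a 1.2-fold higher number from compound 2 to compound 3 (0.10 log units; within the scatter), both lie within the scatter, as does a 1.1-fold lower number from compound 1 to compound 3 (0.03 log units; within the scatter), so the three numbers cannot be told apart in this assay.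

Compound 4 `Cc1ccccc1C(=O)Nc1sc2c(c1C(N)=O)CCN(C(=S)Nc1ccccc1C(F)(F)F)C2` has not yet been measured. It differs from compound 2 in one place: trifluoromethyl in place of chloro on an aromatic carbon. Among the compounds with values here, all three measured steps change the ring on the carbonyl carbon of the shared core and leave the thiourea-linked aryl untouched, so no measured step bears directly on this change. What the measured steps do show is that substituent changes on the other ring, whether bromo, methyl or 4-(trifluoromethyl)phenyl, moved this assay little, every step staying within the scatter. Within the data shown here, with no direct precedent for the thiourea-linked ring, the expectation for compound 4 is no step beyond the scatter, a 1.1-fold higher number from compound 2 to compound 4 (0.05 log units; within the scatter). Compound 4 is therefore estimated at 40000 nM in this assay, with a range from 15000 nM to 100000 nM.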

Compound 4, half-maximal inhibitory concentration: > 50000 nM
Compound 4: only a limit was reported; the forecaster's own chance of this, stated with the estimate: 20%; at least 1.2-fold (0.09 log units) between middle value and limit.
By their numbers in this assay, from the lowest: compounds 2, 3 and 1 (each within the scatter of the next). At a limit, above all of these: compound 4.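

Within the data shown here, the exchange of chloro for trifluoromethyl, ortho to a large group, gives an at least 1.4-fold higher number from compound 2 to compound 4 (0.15 log units; that floor lies within the scatter), the first reading at this position, since the earlier steps all changed the ring on the carbonyl carbon. For compound 4 in this assay there is only a limit, > 50000 nM, so this change has a floor and no measured size. That floor neither shows that this position responds more strongly than the ring on the carbonyl carbon nor rules out a larger step, and the reading rests on a single compound: the limit of > 50000 nM in this assay, at which 1 of the 4 values shown sits.

Still open, on these data alone, is whether another group at this place, such as an amine or a carboxylic acid, would give a number that can be read in this assay and so show how this position responds. Also open is whether the exchange of chloro for trifluoromethyl reads the same with 2-bromophenyl or 4-(trifluoromethyl)phenyl on the carbonyl carbon, since it is shown here only with 2-methylphenyl there.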